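Trimming the Amine in a Cytotoxicity Check

The source may hold more compounds than are shown below. What is called first, only, known or untested is meant among the compounds shown, and "the series" means these compounds.

Compound 1 `Cc1ccc(-c2nc3ccccc3s2)cc1NC(=O)c1cc([N+](=O)[O-])c(N2CCCCC2)cc1Cl` is one of three compounds tested in an ADME assay on BJ cells (Homo sapiens) for cytotoxicity, with a stated time of 72 h; a lower number here means that less compound is needed, a higher number that more compound is needed for the effect. There compound 1 reaches only a limit, > 25000 nM. Compound 2 `O=C(Nc1cccc(-c2nc3ccccc3s2)c1)c1cc([N+](=O)[O-])ccc1Cl` likewise gives only a limit in this assay, > 27000 nM. Compound 3 `O=C(Nc1cccc(-c2nc3ccccc3o2)c1)c1cc([N+](=O)[O-])ccc1Cl` also stops at a limit, > 25000 nM. Within the data shown here, the single comparison in which two measured compounds differ in one place, a step that the two limits leave unreadable from compound 2 to compound 3, cannot be read for size. Compound 4 `Cc1ccc(-c2nc3ccccc3s2)cc1NC(=O)c1cc([N+](=O)[O-])c(N(C)C)cc1Cl` differs from compound 1 by dimethylamino in place of piperidin-1-yl on an aromatic carbon. Among the measured compounds shown here, no measured step touches this change, and every value shown sits at a limit (the limit of > 25000 nM in this assay, at which 2 of the 3 values shown sit, (the limit of > 27000 nM in this assay, at which 1 of the 3 values shown sits)), so no step beyond the scatter is expected in this assay. Compound 4 is expected to give about 25000 nM, within a range from 12000 nM to 50000 nM. The expected step of a number no higher from compound 1 to compound 4 (the limit leaves the size open) is essentially none, most likely ending again at a limit.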

Compound 4, half-maximal effective concentration: > 25000 nM
Compound 4: no number, only a limit; the forecaster's own chance of this, stated with the estimate: 85%; the middle value sits exactly at the limit.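

Compound 1 and compound 4 both end at a limit in this assay, and the step between them cannot be read. The compounds shown leave open what concentration of any of them would produce the effect.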